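The source may hold more compounds than are shown below. What is called first, only, known or untested is meant among the compounds shown, and "the series" means these compounds.

Measured compounds:
compound 1 `O=C(Nc1cccc(-n2cc(-c3ccncc3)c(-c3ccc(Cl)c(O)c3)n2)c1)Nc1ccc(Cl)c(Cl)c1`: > 32500 nM
compound 2 `COc1cc(-c2nn(-c3cccc(NC(=O)Nc4ccc(Cl)c(C(F)(F)F)c4)c3)cc2-c2ccncc2)ccc1Cl`: > 32500 nM

In a functional assay on MDA-MB-435 cells (Homo sapiens) for inhibition, read by sulforhodamine B assay, with a stated time of 48 h (on this read-out higher numbers stand for lower toxicity in this test and lower numbers for higher toxicity in this test), compound 1 reaches only the limit of the assay, > 32500 nM. In this assay compound 2 likewise reaches only a limit, > 32500 nM. As the limit of > 32500 nM in this assay, at which 2 of the 2 values shown sit, shows, compound 2 stands at the limit, and nothing separates it from compound 1. Compound 3 `O=C(Nc1cccc(-n2cc(-c3ccncc3)c(-c3ccc(Cl)c(O)c3)n2)c1)Nc1ccc(Cl)c(C(F)(F)F)c1` differs from compound 2 by hydrogen in place of methyl on an oxygen on an aromatic ring. Compound 1 carries the 4-chloro-3-hydroxyphenyl group too, so no step beyond the scatter is expected. The expected step is a number no higher from compound 2 to compound 3 (the limit leaves the size open). Compound 3 is expected at 32500 nM, between 15000 nM and 100000 nM, most likely again only a limit.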

Compound 3, concentration lethal to 50% of the cells: 21500 nM
Beside the measured number, compound 3's estimate is 1.5-fold (0.18 log units) above it; measured number inside the range.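

In this assay compound 3 is the first of these compounds to read as a number and not as a limit, which puts the pairing of hydroxy with trifluoromethyl on the scale. Methoxy to hydroxy gives an at least 1.5-fold lower number from compound 2 to compound 3 (0.17 log units; that floor lies within the scatter), and trifluoromethyl in place of chloro gives an at least 1.5-fold lower number from compound 1 to compound 3 (0.17 log units; that floor lies within the scatter), so neither change is shown to matter on its own. The true size of both steps stays unread because one partner in each pair is only a limit: the limit of > 32500 nM in this assay, at which 2 of the 3 values shown sit.

On these data alone, whether an ethoxy group or an amine in place of the hydroxy would move the number stays open.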